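This account rests on a few compounds, and the source may have more. Where it says the series, first, only, none or still open, it means among the compounds named here.

Compound 1, with the structure `CCCCCCCCCCC(=O)OCCc1ccc(O)c(O)c1`, is one of three compounds tested in a toxicity assay on MRC5 cells (Homo sapiens) for inhibition, read by MTT assay, with a stated time of 72 h (on this read-out lower numbers stand for stronger inhibition and higher numbers for weaker inhibition), and its result there is not a number but a limit: compound 1 gives > 50000 nM. Compound 2, with the structure `CCCCCCCCCCCCSCCc1ccc(OCc2ccc(OC)cc2)c(OCc2ccc(OC)cc2)c1`, also returns only a limit, giving > 50000 nM in this assay. Compound 3, with the structure `CC(=O)OCCc1ccc(O)cc1`, is the only one of the three with a numeric value, giving 114000 nM in this assay. Going by the values given here, compound 1 therefore stands where two of the three results stand, at the limit of > 50000 nM in this assay, at which 2 of the 3 values shown sit, and no step between it and either of the other two compounds can be computed, since no measured pair differs in a single place.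

Compound 4, with the structure `CCCCCCCCCCCCC(=O)OCCc1ccc(O)c(O)c1`, has not yet been tested in this assay. It differs from compound 1 by ethyl in place of hydrogen on a saturated chain carbon, ten or more bonds along the chain from a carbonyl carbon. Among the compounds with values here, with no measured step to draw on, and with compound 1 sitting at the limit of > 50000 nM in this assay, at which 2 of the 3 values shown sit, the expected step from compound 1 to compound 4 in this assay is a step that the limit leaves unreadable from compound 1 to compound 4, that is, no shift beyond the usual scatter in either direction. Compound 4 is accordingly expected to give about 60000 nM in this assay, within a range of 30000 nM to 150000 nM, most likely reported once more as a limit rather than a number.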

Compound 4, half-maximal inhibitory concentration: 13200 nM
Compound 4: the middle estimate sits 4.5-fold (0.66 log units) above what was measured; measured number outside the range, below it.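

Going by these compounds alone, this is the first step in the set that can be read at all, and it shows that the far end of the chain is not a silent place in this assay: ethyl in place of hydrogen on a saturated chain carbon, ten or more bonds along the chain from a carbonyl carbon, gives an at least 3.7-fold lower number from compound 1 to compound 4 (0.57 log units; beyond the scatter), a move towards stronger inhibition. The change is small by count, with 2 carbon atoms entering and no ring, no hydrogen-bond donor or acceptor and no net charge, and yet it lies beyond the scatter. The step is a bound and not an exact size, because compound 1 has only a limit in this assay: the limit of > 50000 nM in this assay, at which 2 of the 4 values shown sit.

The compounds shown leave open whether a longer chain at this place would carry the number lower still, or whether an amine or a carboxylic acid at the chain end would shift it at all. They also leave open whether the step would hold with an amide in place of the ester, since this single pair is the only one that can be read.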